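Replacing the methyl of compound 1 with phenyl

A few compounds are considered here, and "the series" means these few. Any claim that something is new, unique, unknown or untested is made for them only; others in the source may bear on it.

Compound 1 `Cc1cc(Nc2ccc(C(=O)/C=C/c3ccc4ccccc4c3)cc2)n2ncnc2n1`: 730 nM
Compound 2 `Cc1cc(Nc2ccc(C(=O)/C=C/c3ccc4ccccc4c3)cc2)n2nc(SCc3ccc(C(F)(F)F)cc3)nc2n1`: 1450 nM

For the measured compounds named here, in a functional assay on SW-620 cells (Homo sapiens) for cytotoxicity, read by MTT assay, with stated times of 4 h and 72 h, tested at 10 uM (on this read-out higher numbers stand for weaker inhibition and lower numbers for stronger inhibition), compound 1 gives 730 nM, which lies within the scatter of compound 2 at 1450 nM, the only other measured compound. The next compound to be tested is compound 3 `O=C(/C=C/c1ccc2ccccc2c1)c1ccc(Nc2cc(-c3ccccc3)nc3ncnn23)cc1`. Relative to compound 1, it carries phenyl in place of methyl on an aromatic carbon.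

Going by the values given here, only one measured step bears on this change, and it does so indirectly. In that step, (4-(trifluoromethyl)benzyl)sulfanyl takes the place of hydrogen on an aromatic carbon, giving a 2.0-fold higher number from compound 1 to compound 2 (0.30 log units; within the scatter). A much larger group was thus added without a shift beyond the scatter, but that step leaves the methyl in place. No measurement shows what happens when the methyl is replaced, so the expectation remains loose. No step beyond the scatter is expected in this assay. The estimate is a 1.4-fold higher number from compound 1 to compound 3 (0.14 log units; within the scatter). For compound 3, the expected value is 1000 nM, with an estimated range from 350 nM to 3000 nM.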

Compound 3, half-maximal inhibitory concentration: 790 nM
Compound 3: middle estimate off by 1.3-fold (0.10 log units), on the high side, and the stated range covers the measured number.
By their numbers in this assay, from the lowest: compounds 1, 3 and 2 (each within the scatter of the next).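

In this assay, for the compounds shown here, the step at this position reads a 1.1-fold higher number from compound 1 to compound 3 (0.03 log units; within the scatter) and gives the first direct measurement of a change at the aromatic carbon that carries the methyl in compound 1. Exchanging that methyl for phenyl adds a six-membered aromatic ring of carbon only, yet the read-out does not move beyond the scatter, which the earlier step, made elsewhere on the shared core, could only hint at. Nothing measured accounts for why this larger group leaves the number within the scatter.

Methyl and phenyl both lack hydrogen-bond donors and acceptors, so it remains open whether an amine, a carboxylic acid or a longer alkyl chain at this position would also stay within the scatter of compound 1. It is equally open whether phenyl at this position and (4-(trifluoromethyl)benzyl)sulfanyl on the same core would together give a number close to those of the compounds shown here.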